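Adding a Hydroxymethylethyl Arm to the Dimethylamino Group

This account rests on a few compounds, and the source may have more. Where it says the series, first, only, none or still open, it means among the compounds named here.

Compound 1 `OCCCNc1ncnc2[nH]cc(-c3cccc(Cl)c3)c12`: 94 nM in an assay for inhibition of serine/threonine-protein kinase 4 (Homo sapiens), read by luminescence and ADP-Glo, in the presence of a further agent that is not named here; on this read-out higher numbers stand for weaker inhibition and lower numbers for stronger inhibition
Compound 2 `CC1(O)CCN(c2ncnc3[nH]cc(-c4cccc(Cl)c4)c23)CC1`: 145 nM
Compound 3 `CN(C)c1ncnc2[nH]cc(-c3cccc(Cl)c3)c12`: 81 nM

Compound 3 gives the lowest of the three numbers, yet the steps of a 1.2-fold lower number from compound 1 to compound 3 (0.06 log units; within the scatter) and a 1.8-fold lower number from compound 2 to compound 3 (0.25 log units; within the scatter) both lie within the scatter, so none of the three stands apart from the others. Compound 4 `CC(CO)CN(C)c1ncnc2[nH]cc(-c3cccc(Cl)c3)c12` has not been measured; it differs from compound 3 by 1-(hydroxymethyl)ethyl in place of hydrogen on a saturated chain carbon bound to a nitrogen on an aromatic ring. Those same two steps bear on this change: each swaps one hydroxyl-bearing group on the nitrogen on the aromatic ring for another and stays within the scatter. Compound 4, which keeps a hydroxyl-bearing chain on that nitrogen, is therefore expected to show no step beyond the scatter in this assay, with a 1.2-fold higher number from compound 3 to compound 4 (0.07 log units; within the scatter). Compound 4 is estimated at 95 nM, between 45 nM and 200 nM.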

Compound 4, half-maximal inhibitory concentration: 38 nM
Compound 4: the middle estimate sits 2.5-fold (0.40 log units) above what was measured; the whole stated range lies above it.
By their numbers in this assay, from the lowest: compound 4; then compounds 3, 1 and 2 (each within the scatter of the next).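

In this assay, for the compounds shown here, the 1-(hydroxymethyl)ethyl group in place of hydrogen gives a 2.1-fold lower number from compound 3 to compound 4 (0.33 log units; beyond the scatter) and is the first change here to pass beyond the scatter. Compound 4 also separates from the other two hydroxyl-bearing compounds, with a 3.8-fold lower number from compound 2 to compound 4 (0.58 log units; beyond the scatter) and a 2.5-fold lower number from compound 1 to compound 4 (0.39 log units; beyond the scatter) on the same aromatic carbon, so the group placed there is no longer without consequence. Nothing measured here accounts for this gain.

As far as these compounds go, whether the hydroxyl is needed at all remains open. So does what a methyl ether, an amine or a carboxylic acid at the end of that chain would give.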